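This account rests on a few compounds, and the source may have more. Where it says the series, first, only, none or still open, it means among the compounds named here.

For the measured compounds named here, compound 1 `Cc1nc(-c2ccc(C(F)(F)F)cc2)sc1CNc1ccc(/C=C/C(=O)O)cc1` is one of two compounds measured in a functional assay on CHO cells for agonist activity at Free fatty acid receptor 1 (Homo sapiens) (a lower number here means that less compound is needed, a higher number that more compound is needed for the effect), where compound 1 gives 36.3 nM. Going by the values given here, the only comparison is compound 2 `O=C(O)[C@@H]1C[C@H]1c1ccc(NCc2cccc(Oc3ccccc3)c2)cc1`, which in this assay gives 562 nM; compound 1 stands at the lower of the two numbers, and the gap between them lies beyond the usual scatter. Compound 3 `Cc1nc(-c2ccc(C(F)(F)F)cc2)sc1CNc1ccc(CCC(=O)NC(C)C)cc1` has not yet been measured. It keeps the core of compound 1 and changes one group: 2-(isopropylcarbamoyl)ethyl in place of 2-carboxyethenyl on an aromatic carbon. This exchanges a carboxylic acid carried on a double bond for an isopropyl amide on a saturated two-carbon chain. Without a measured pair showing such a change, the expectation rests on the structures alone, and an upward step of some size from compound 1 to compound 3, estimated as a 110-fold higher number from compound 1 to compound 3 (2.04 log units; beyond the scatter), is expected. For compound 3 in this assay the expected value is 4000 nM, within an estimated range from 1000 nM to 20000 nM.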

Compound 3, half-maximal effective concentration: 100 nM
Estimate against measurement, compound 3: 40-fold (1.60 log units) above; measured number outside the range, below it.
By their numbers in this assay, from the lowest: compound 1; then compound 3; then compound 2.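

In this assay the exchange of 2-carboxyethenyl for 2-(isopropylcarbamoyl)ethyl on the aromatic carbon para to a large group gives a 2.8-fold higher number from compound 1 to compound 3 (0.44 log units; beyond the scatter) and so moves the number only modestly, even though the step lies beyond the scatter. The carboxylic acid of compound 1 is therefore not essential for activity here, since compound 3, which carries an isopropyl amide on a saturated chain instead, still gives 100 nM in this test. No measurement at hand explains the size of this step.

As far as these compounds go, the exchange alters the acid and the double bond together, so the share of each in the step stays open. A 2-carboxyethyl group, with the carboxylic acid on the saturated chain, or an isopropyl amide carried on the double bond would separate the two changes.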